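Swapping a Chlorophenyl for a Fluorophenyl

The source may hold more compounds than are shown below. What is called first, only, known or untested is meant among the compounds shown, and "the series" means these compounds.

Compound 1 `O=C(N/N=C/c1c(-c2cc3ccccc3oc2=O)[nH]c2ccccc12)c1ccccc1` gives in a functional assay on MCF7 cells (Homo sapiens) for inhibition, read by MTT assay, with a stated time of 48 h; a lower number here means a stronger inhibitor, a higher number a weaker inhibitor > 200000 nM, which is a limit of the assay rather than a number.
Compound 2 `O=C(N/N=C/c1c(-c2cc3ccccc3oc2=O)[nH]c2ccccc12)c1ccc(Cl)cc1` gives in this assay > 200000 nM, again a limit of the assay.
Compound 3 `O=C(N/N=C/c1c(-c2cc3ccccc3oc2=O)[nH]c2ccccc12)c1ccccc1Cl` gives in this assay 164000 nM.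

Compound 2 thus stands at the limit, where two of the three values sit (the limit of > 200000 nM in this assay, at which 2 of the 3 values shown sit); only compound 3 has a readable number. Compound 4 `O=C(N/N=C/c1c(-c2cc3ccccc3oc2=O)[nH]c2ccccc12)c1ccccc1F` differs from compound 2 in one place: 2-fluorophenyl in place of 4-chlorophenyl on a carbonyl carbon. The step that the two limits leave unreadable from compound 1 to compound 2 has both ends at the limit and cannot be read. For the measured compounds named here, the steps of an at least 1.2-fold lower number from compound 2 to compound 3 (0.08 log units; that floor lies within the scatter) and an at least 1.2-fold lower number from compound 1 to compound 3 (0.08 log units; that floor lies within the scatter) both reach compound 3 and both are floors within the scatter, so no measured step shows a change beyond the scatter. Compound 4 carries 2-fluorophenyl where compound 3 carries 2-chlorophenyl. Compound 4 is therefore expected to sit near the limit, at an estimated 180000 nM (from 100000 nM to 320000 nM), and the expected step of an at least 1.1-fold lower number from compound 2 to compound 4 (0.04 log units; that floor lies within the scatter) would stay within the scatter.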

Compound 4, half-maximal inhibitory concentration: > 200000 nM
Compound 4 was reported as a limit; the forecaster's own chance of this, stated with the estimate: 50%; at least 1.1-fold (0.04 log units) between middle value and limit.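

In this assay compound 4 gives a limit of the assay rather than a number, so the 2-fluorophenyl group does not yield a readable value at this place on the carbonyl carbon: the limit of > 200000 nM in this assay, at which 3 of the 4 values shown sit. Fluoro in place of chloro on the aromatic carbon gives an at least 1.2-fold higher number from compound 3 to compound 4 (0.08 log units; that floor lies within the scatter), so this change shows nothing beyond the scatter, and a floor cannot tell how large the true step is. The steps joining compound 4 to compound 1 and compound 2 have limits at both ends and cannot be read.

From the compounds shown here alone, how far compound 1, compound 2 and compound 4 lie past the limit stays open. Also open, going by these compounds, is what an amine or a carboxylic acid on the phenyl ring, or a longer chain in place of that ring, would do to the number.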